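This account rests on a few compounds, and the source may have more. Where it says the series, first, only, none or still open, it means among the compounds named here.

Measured in a functional assay on PC-3 cells (Homo sapiens) for antiproliferative activity, read by MTT assay, with a stated time of 48 h; a lower number here means a stronger inhibitor, a higher number a weaker inhibitor:
compound 1 `CCn1c(C(=O)Nc2cccc(C(F)(F)F)c2)ccc1C(CC)(CC)c1ccc(OCCC(O)(CC)CC)c(C)c1`: 23800 nM
compound 2 `CCOC(=O)C(CC(=O)OC)NC(=O)c1ccc(C(CC)(CC)c2ccc(OCCC(O)(CC)CC)c(C)c2)n1CC`: 5840 nM
compound 3 `CCn1c(C(=O)N(C)CC(=O)O)ccc1C(CC)(CC)c1ccc(OCCC(O)(CC)CC)c(C)c1`: 2250 nM

Compound 3 has the lowest number of the three. Compound 4 `CCn1c(C(=O)NC(CC(=O)O)C(=O)OC)ccc1C(CC)(CC)c1ccc(OCCC(O)(CC)CC)c(C)c1` alters it in one place: a group of 10 heavy atoms (5 carbon, 1 nitrogen, 4 oxygen; no ring) in place of a group of 6 heavy atoms (3 carbon, 1 nitrogen, 2 oxygen; no ring), on a carbonyl carbon. The closest guide is a 2.6-fold lower number from compound 2 to compound 3 (0.41 log units; beyond the scatter), a modest step between two groups without a ring. The other step, an 11-fold lower number from compound 1 to compound 3 (1.02 log units; beyond the scatter), is large, but it removes an aromatic ring, so it bears less on this change. The new group carries both a free carboxylic acid, as in compound 3, and an ester, as in compound 2. A number between those of these two compounds therefore seems likely, nearer the lower one. The expected change in this assay is small and upward: a 1.6-fold higher number from compound 3 to compound 4 (0.19 log units; within the scatter). The estimate for compound 4 is 3500 nM, within a range of 1200 nM to 10000 nM.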

Compound 4, half-maximal inhibitory concentration: 11200 nM
For compound 4 the middle estimate is 3.2-fold (0.51 log units) below the measured one; measured number outside the range, above it.
By their numbers in this assay, from the lowest: compound 3; then compounds 2 and 4 (each within the scatter of the next); then compound 1.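

In this assay, a free carboxylic acid on this carbonyl carbon does not by itself give a low number: adding an ester alongside it costs activity, with a 5.0-fold higher number from compound 3 to compound 4 (0.70 log units; beyond the scatter). Swapping one of the two esters of compound 2 for the acid hardly matters, with a 1.9-fold higher number from compound 2 to compound 4 (0.28 log units; within the scatter). Even so, this ester-acid group still improves on the (3-(trifluoromethyl)phenyl)amino group, with a 2.1-fold lower number from compound 1 to compound 4 (0.33 log units; beyond the scatter). How an amine in place of the carboxylic acid would behave here stays open, and nothing given accounts for these steps.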